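A few compounds are considered here, and "the series" means these few. Any claim that something is new, unique, unknown or untested is made for them only; others in the source may bear on it.

Measured in a functional assay on DLD-1 cells (Homo sapiens) for antiproliferative activity, read by CellTiter-Glo, with a stated time of 72 h; a lower number here means a stronger inhibitor, a higher number a weaker inhibitor:
- compound 1 `CC1CCN(C2CCN(S(=O)(=O)c3ccccc3Br)CC2)CC1`: 3 nM
- compound 2 `Cc1nc(Cl)sc1S(=O)(=O)N1CCC(N2CCC(C)CC2)CC1`: 1.6 nM

Compound 2 gives the lowest of the two numbers in this assay, but the step of a 1.9-fold lower number from compound 1 to compound 2 (0.27 log units; within the scatter) is within the scatter, so the two values cannot be ordered. Compound 3 `CC1CCN(C2CCN(S(=O)(=O)c3cncc(Br)c3)CC2)CC1` differs from compound 2 by 5-bromopyridin-3-yl in place of 2-chloro-4-methyl-1,3-thiazol-5-yl on a sulfonyl sulfur. Among the compounds with values here, the only measured step touching the group on the sulfonyl sulfur, from compound 1 to compound 2, was within the scatter, so no step beyond the scatter is expected here either. Compound 3 is estimated at 3 nM in this assay, range 1 nM to 10 nM. The expected step is a 1.9-fold higher number from compound 2 to compound 3 (0.27 log units; within the scatter).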

Compound 3, half-maximal inhibitory concentration: > 5000 nM
Compound 3: a limit, no number; the forecaster's own chance of this, stated with the estimate: 2%; at least 1600-fold (3.22 log units) between middle value and limit.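

In this assay compound 3 stands at a limit, not a number: the limit of > 5000 nM in this assay, at which 1 of the 3 values shown sits. The group on a sulfonyl sulfur is not freely exchangeable: 5-bromopyridin-3-yl gives an at least 3100-fold higher number from compound 2 to compound 3 (3.49 log units; beyond the scatter), and against 2-bromophenyl it gives an at least 1600-fold higher number from compound 1 to compound 3 (3.22 log units; beyond the scatter). Within the data shown here, the only earlier step at this place, a 1.9-fold lower number from compound 1 to compound 2 (0.27 log units; within the scatter), gave no sign of such a loss.

The compounds shown leave open whether the ring nitrogen or the place of the bromine goes with the loss. A 3-bromophenyl group on the sulfonyl sulfur would separate the two.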